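A few compounds are considered here, and "the series" means these few. Any claim that something is new, unique, unknown or untested is made for them only; others in the source may bear on it.

Compound 1 `Cc1ccc(Nc2nc(C)c(C(=O)/C=C/c3ccc(Cl)cc3)s2)cc1`, compound 2 `Cc1ccc(Nc2nc(C)c(C(=O)/C=C/c3ccccc3)s2)cc1` and compound 3 `Cc1nc(Nc2ccccc2)sc1C(=O)/C=C/c1ccccc1Cl` have been measured in a functional assay on Bel-7402 cells (Homo sapiens) for cytotoxicity, read by MTT assay; a lower number here means a stronger inhibitor, a higher number a weaker inhibitor.

In this assay compound 1 returns only a limit, > 25000 nM. Compound 2 likewise returns only a limit, > 25000 nM. Compound 3 also returns only a limit, > 25000 nM. Compound 2 therefore stands where its two companions stand, at the limit of > 25000 nM in this assay, at which 3 of the 3 values shown sit, with no number of its own to place it more closely.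

Compound 4 `Cc1ccccc1Nc1nc(C)c(C(=O)/C=C/c2ccccc2)s1` has not yet been measured in this assay. It differs from compound 2 by 2-methylphenyl in place of 4-methylphenyl on a nitrogen on an aromatic ring. Going by the values given here, only one step between measured compounds that differ in a single place is available, a step that the two limits leave unreadable from compound 1 to compound 2, and it is unreadable, as the two values it joins are both limits. Among the compounds with values here, no measured step touches the group that changes here, and none gives a readable size for any change at all.

On these numbers there is no ground to expect compound 4 to leave the limit. The expected step that the limit leaves unreadable from compound 2 to compound 4 is accordingly none beyond the scatter. Compound 4 is estimated at 35000 nM, within a range from 10000 nM to 120000 nM, and the result is most likely again to be reported only as a limit.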

Compound 4, half-maximal inhibitory concentration: > 25000 nM
Compound 4: no number, only a limit; the forecaster's own chance of this, stated with the estimate: 85%; the middle value does not contradict the limit.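

In this assay compound 4 returns only a limit, > 25000 nM. Going by these compounds alone, compound 2 also returns only a limit, so no step between compound 2 and compound 4 can be read. The compounds shown leave open whether 2-methylphenyl and 4-methylphenyl differ at all in this read-out, and what any of these compounds' actual values are, as all rest at one point: the limit of > 25000 nM in this assay, at which 4 of the 4 values shown sit.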